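This account rests on a few compounds, and the source may have more. Where it says the series, first, only, none or still open, it means among the compounds named here.

Measured compounds:
Compound 1 `COc1cccc(NC2=CC(=O)c3nc4n(c3C2=O)[C@H]2OC[C@@H](O)[C@H]2OC4)c1`: 4280 nM
Compound 2 `CCOc1ccccc1NC1=CC(=O)c2c(nc3n2[C@H]2OC[C@@H](O)[C@H]2OC3)C1=O`: 8300 nM
Compound 3 `O=C1C(N2CCCC2)=CC(=O)c2c1nc1n2[C@H]2OC[C@@H](O)[C@H]2OC1`: > 16000 nM (a limit)

All three share one core and differ only in the group on the amine nitrogen. In a functional assay on HeLa cells (Homo sapiens) for inhibition, read by sulforhodamine B assay (on this read-out lower numbers stand for stronger inhibition and higher numbers for weaker inhibition), compound 1 gives 4280 nM. In this assay compound 2 gives 8300 nM, a value within the scatter of compound 1, so the two cannot be ranked against each other. For compound 3 the result is not a number but a limit, (the limit of > 16000 nM in this assay, at which 1 of the 3 values shown sits), and compound 3 is the only one of the three that reaches it. Compound 1 thus holds the lowest of the two real numbers, but without a clear gap to compound 2.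

Compound 4 `CCOc1ccc(NC2=CC(=O)c3nc4n(c3C2=O)[C@H]2OC[C@@H](O)[C@H]2OC4)cc1` has not yet been measured. It differs from compound 1 in one place: 4-ethoxyphenyl in place of 3-methoxyphenyl on an amine nitrogen. Nothing among the three measured compounds shows this exact change, so only the range of the two real numbers gives a footing. The step from compound 1 to compound 4 is expected to be small, a 1.4-fold higher number from compound 1 to compound 4 (0.15 log units; within the scatter), towards a slightly weaker value at most, and not certainly beyond the scatter. Compound 4 is estimated at 6000 nM, between 2000 nM and 18000 nM.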

Compound 4, half-maximal inhibitory concentration: 3110 nM
Compound 4: the middle estimate sits 1.9-fold (0.29 log units) above what was measured; low and high end bracket the measured number.
By their numbers in this assay, from the lowest: compounds 4, 1 and 2 (each within the scatter of the next, the first and the last beyond it). At a limit, above all of these: compound 3.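

Putting 4-ethoxyphenyl in place of 3-methoxyphenyl on the amine nitrogen gives a 1.4-fold lower number from compound 1 to compound 4 (0.14 log units; within the scatter), so this assay cannot tell these two groups apart. Within the data shown here, this is the first direct comparison of two compounds in which this swap is the only difference, and it shows that the two alkoxy-substituted phenyl groups give values that cannot be separated on the shared core. Nothing measured here gives a reason for this step.

The swap alters both the place of the alkoxy group on the ring and its chain, methoxy to ethoxy, so this pair cannot show what either alteration does alone. A 4-methoxyphenyl or 3-ethoxyphenyl group would separate the two, and the compounds shown leave open what a carboxylic acid or an amine on the same ring would do.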